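The source may hold more compounds than are shown below. What is called first, only, known or untested is meant among the compounds shown, and "the series" means these compounds.

Compound 1 `Cc1ccc(C2=NNC(c3ccc(N4CCCCC4)cc3)C2)s1` gives 15300 nM in an ADME assay on CCRF-CEM cells (Homo sapiens) for cytotoxicity, with a stated time of 5 days; on this read-out lower numbers stand for stronger inhibition and higher numbers for weaker inhibition.
Compound 2 `Cc1cc(C2=NNC(c3ccc(N4CCCCC4)cc3)C2)c(C)s1` gives 20100 nM in this assay.
Compound 3 `Clc1ccc(C2=NNC(c3ccc(N4CCCCC4)cc3)C2)s1` gives only a limit of the assay, > 100000 nM, in this assay.

Compound 3 thus stands at the weak end of the set, sitting at the limit of > 100000 nM in this assay, at which 1 of the 3 values shown sits. The steps of an at least 6.5-fold higher number from compound 1 to compound 3 (0.81 log units; beyond the scatter) and an at least 4.9-fold higher number from compound 2 to compound 3 (0.69 log units; beyond the scatter) both lie beyond the scatter, whereas a 1.3-fold higher number from compound 1 to compound 2 (0.12 log units; within the scatter) stays within it. Compound 4 `Brc1ccc(C2=NNC(c3ccc(N4CCCCC4)cc3)C2)s1` differs from compound 3 by bromo in place of chloro on an aromatic carbon. Among the measured compounds shown here, no measured step exchanges one halogen for another, so the closest guide is an at least 6.5-fold higher number from compound 1 to compound 3 (0.81 log units; beyond the scatter), which only shows that compound 3 already sits at the limit. Compound 4 is therefore expected to move little, a step that the limit leaves unreadable from compound 3 to compound 4, in this assay. The estimate for compound 4 is 150000 nM, within 50000 nM to 450000 nM, most likely reported again as a limit.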

Compound 4, half-maximal inhibitory concentration: 21500 nM
Beside the measured number, compound 4's estimate is 7.0-fold (0.84 log units) above it; the measured number lies below the stated range.
By their numbers in this assay, from the lowest: compounds 1, 2 and 4 (each within the scatter of the next). At a limit, above all of these: compound 3.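

On the aromatic carbon next to the ring sulfur, the two halogens do not read alike in this assay: an at least 4.6-fold lower number from compound 3 to compound 4 (0.66 log units; beyond the scatter). Bromo shows no separation from methyl, a 1.4-fold higher number from compound 1 to compound 4 (0.15 log units; within the scatter), nor from 2,5-dimethylthiophen-3-yl, a 1.1-fold higher number from compound 2 to compound 4 (0.03 log units; within the scatter). Compound 3, with chloro, alone remains at a limit of the assay: the limit of > 100000 nM in this assay, at which 1 of the 4 values shown sits.

On these data alone, what a methoxy group, a nitrile or an amine on this carbon would give stays open. So does an exact number for compound 3.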